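Amide Tail Swapped from Tert-Butyl to Pentyl

A few compounds are considered here, and "the series" means these few. Any claim that something is new, unique, unknown or untested is made for them only; others in the source may bear on it.

Three measured compounds share one core and differ only in the group on the amide-type nitrogen. Compound 1 `C=CC1=C(C(=O)NCc2ccc(C)cc2)C(c2ccc(F)cc2)OC1` carries a 4-methylbenzyl group there. In a functional assay on HeLa cells (Homo sapiens) for cytotoxicity, read by MTT assay, with a stated time of 24 h (a higher number here means a weaker inhibitor, a lower number a stronger inhibitor), compound 1 reaches only a limit of the assay, > 100000 nM. Compound 2 `C=CC1=C(C(=O)NCc2ccc(Cl)cc2)C(c2ccc(F)cc2)OC1` carries a 4-chlorobenzyl group. In this assay compound 2 likewise sits at a limit, > 100000 nM. Compound 3 `C=CC1=C(C(=O)NC(C)(C)C)C(c2ccc(F)cc2)OC1` carries a tert-butyl group. In this assay compound 3 again gives only a limit, > 100000 nM. Because all three values sit at the limit of > 100000 nM in this assay, at which 3 of the 3 values shown sit, the steps between them cannot be sized: a step that the two limits leave unreadable from compound 1 to compound 2, a step that the two limits leave unreadable from compound 1 to compound 3 and a step that the two limits leave unreadable from compound 2 to compound 3 are all unreadable. On these numbers compound 3 cannot be told apart from the other two.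

Compound 4 `C=CC1=C(C(=O)NCCCCC)C(c2ccc(F)cc2)OC1` differs from compound 3 by pentyl in place of tert-butyl on an amide-type nitrogen. Among the measured compounds shown here, no measured step bears on this change in a readable way, since every one of them is hidden behind the same limit. For the measured compounds named here, the expectation for compound 4 therefore rests only on the fact that none of the measured compounds shows a number under that limit. Compound 4 is expected to give about 150000 nM in this assay, with a range from 60000 nM to 400000 nM, most likely reported once more as a limit. The expected step is a step that the limit leaves unreadable from compound 3 to compound 4, that is, nothing beyond the scatter.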

Compound 4, half-maximal inhibitory concentration: > 100000 nM
Compound 4: only a limit was reported; the forecaster's own chance of this, stated with the estimate: 85%; the middle value lies beyond the limit too.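

In this assay compound 4 also gives only a limit, > 100000 nM. The steps joining compound 4 to compound 1, compound 2 and compound 3 therefore cannot be read, as all four compounds share one limit: the limit of > 100000 nM in this assay, at which 4 of the 4 values shown sit.

The compounds shown leave open whether any group on the amide-type nitrogen of the shared core can give a measurable value in this assay.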